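A few compounds are considered here, and "the series" means these few. Any claim that something is new, unique, unknown or untested is made for them only; others in the source may bear on it.

The series shares one core, seen in compound 1 `CC(=O)NCC[C@@H]1C[C@@H](c2ccc(F)c(F)c2)[C@H](NC(=O)c2cc(-c3c(Cl)cnn3C)c(Cl)o2)CN1`, compound 2 `Cn1ncc(Cl)c1-c1cc(C(=O)N[C@@H]2CN[C@H](CCO)C[C@H]2c2ccc(F)c(F)c2)oc1Cl` and compound 3 `Cn1ncc(Cl)c1-c1cc(C(=O)N[C@@H]2CN[C@H](CC(=O)O)C[C@H]2c2ccc(Cl)c(Cl)c2)oc1Cl`. In a functional assay on LNCaP cells (Homo sapiens) for antiproliferative activity (on this read-out higher numbers stand for weaker inhibition and lower numbers for stronger inhibition), compound 1 gives 130 nM, compound 2 gives 60 nM and compound 3 gives 640 nM, the highest of the three numbers. Among the compounds with values here, the single step measured within the set, a 2.2-fold lower number from compound 1 to compound 2 (0.34 log units; beyond the scatter), concerns a different exchange out on the chain. Compound 4 `Cn1ncc(Cl)c1-c1cc(C(=O)N[C@@H]2CN[C@H](CC(N)=O)C[C@H]2c2ccc(Cl)c(Cl)c2)oc1Cl` differs from compound 3 by amino in place of hydroxy on a carbonyl carbon. Within the data shown here, no measured step covers an exchange on a carbonyl carbon, so the expectation rests on the change alone. The step is expected to be a 1.3-fold lower number from compound 3 to compound 4 (0.11 log units; within the scatter), with no clear direction beyond the scatter. Compound 4 is therefore estimated at 500 nM in this assay, within 200 nM to 1500 nM.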

Compound 4, half-maximal inhibitory concentration: 160 nM
Compound 4: middle estimate off by 3.1-fold (0.49 log units), on the high side; measured number below the stated range.
By their numbers in this assay, from the lowest: compound 2; then compounds 1 and 4 (each within the scatter of the next); then compound 3.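

Exchanging carboxymethyl for carbamoylmethyl gives a 4.0-fold lower number from compound 3 to compound 4 (0.60 log units; beyond the scatter) in this assay. Within the data shown here, this is the first measured step on this carbonyl carbon, and it shows that the read-out responds to amino in place of hydroxy there, although the exchange swaps one heavy atom and leaves the counted hydrogen-bond donors and acceptors unchanged. Nothing available explains the size of this step.

Still open, as far as these compounds go, is how a methyl ester, an amine or a longer chain would read at this position. Also open, from the compounds shown here alone, is whether the same exchange gives a similar step with the aryl group of compound 2.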